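Hydrazone series: cytotoxicity notes before the hydroxy removal step

The source may report more compounds than this note shows. Statements on the series, on what has been measured and on what is new or still open speak of the compounds shown alone.

In an ADME assay on HEL cells (Homo sapiens) for cytotoxicity (on this read-out higher numbers stand for lower toxicity in this test and lower numbers for higher toxicity in this test), compound 1 `O=C(COc1cccc2ccccc12)N/N=C/c1ccc(O)cc1` gives 20 ug/mL. Compound 2 `C/C(=N\NC(=O)COc1cccc2ccccc12)c1cccc([N+](=O)[O-])c1` gives 20 ug/mL in this assay, level with compound 1 at the digits shown, and the two stand together as the lowest of the three numbers measured. Compound 3 `COc1cc(/C=N/NC(=O)COc2cccc3ccccc23)cc(OC)c1O` gives 100 ug/mL, a number that lies beyond the scatter above that of compound 1. Compound 4 `O=C(COc1cccc2ccccc12)N/N=C/c1ccccc1` has not yet been measured. It differs from compound 1 by hydrogen in place of hydroxy on an aromatic carbon. Among the compounds with values here, no step between two measured compounds isolates this change, so the expectation rests on the cluster formed by compound 1 and compound 2 alone. The step of no change at the digits printed from compound 1 to compound 4 (within the scatter) is expected to stay within the scatter, with no settled direction. Compound 4 is therefore estimated at 20 ug/mL, with a range from 10 ug/mL to 60 ug/mL.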

Compound 4, minimum cytotoxic concentration: 100 ug/mL
Beside the measured number, compound 4's estimate is 5.0-fold (0.70 log units) below it; measured number above the stated range.
By their numbers in this assay, from the lowest: compounds 1 and 2 (each within the scatter of the next); then compounds 3 and 4 (each within the scatter of the next).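

In this assay, within the data shown here, the change from 4-hydroxyphenyl to phenyl gives a 5.0-fold higher number from compound 1 to compound 4 (0.70 log units; beyond the scatter) and is the first step that isolates one place. At this position, on this core, the hydroxy therefore goes with the lower number, meaning higher toxicity in this test, and its loss is not silent. Nothing at hand bears on the cause of this step. From the compounds shown here alone, whether a methoxy group or an amine at this place would read like hydroxy or like hydrogen stays open. Going by these compounds, whether the step carries over to other aryl groups also stays open.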